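Methylsulfonyl on the ring nitrogen of compound 1

This account rests on a few compounds, and the source may have more. Where it says the series, first, only, none or still open, it means among the compounds named here.

Going by the values given here, compound 1 `CC(C)n1[nH]c2ccccc2c1=O` gives 660 nM in an assay on isolated protein (urine) for inhibition of Myeloperoxidase (Homo sapiens), read by spectrophotometry (on this read-out lower numbers stand for stronger inhibition and higher numbers for weaker inhibition), the lowest of the two numbers so far; compound 2 `O=c1c2ccccc2[nH]n1CCO` gives 2470 nM, and the step of a 3.7-fold higher number from compound 1 to compound 2 (0.57 log units; beyond the scatter) arises from 2-hydroxyethyl in place of isopropyl on an aromatic nitrogen. Compound 3 `CC(C)n1c(=O)c2ccccc2n1S(C)(=O)=O` differs from compound 1 by methylsulfonyl in place of hydrogen on an aromatic nitrogen. Among the compounds with values here, no measured step touches this position; the single step seen concerns the other ring nitrogen, so it gives no guide in size or direction. Compound 3 is expected to give a higher number, estimated at 5000 nM within 1500 nM to 20000 nM, the step of a 7.6-fold higher number from compound 1 to compound 3 (0.88 log units; beyond the scatter) being a rough guess.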

Compound 3, half-maximal inhibitory concentration: > 10000 nM
Compound 3: a limit, no number; the forecaster's own chance of this, stated with the estimate: 25%; at least 2.0-fold (0.30 log units) between middle value and limit.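

Methylsulfonyl in place of hydrogen on an aromatic nitrogen gives an at least 15-fold higher number from compound 1 to compound 3 (1.18 log units; beyond the scatter) in this assay, so this position, untouched by the earlier step, is not indifferent to substitution. Compound 3 stands at a limit and not at a number, and the step has no known upper end: the limit of > 10000 nM in this assay, at which 1 of the 3 values shown sits.

With methylsulfonyl as the only replacement for this hydrogen, the compounds shown do not tell whether any group here raises the number or only this one does. A methyl or an acetyl on this nitrogen remains an open case.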